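The compounds below may be only part of what the source reports. "The series", "measured", "known", "first", "only" and "open" are said of these compounds alone.

Measured in a functional assay on HT-29 cells (Homo sapiens) for inhibition, read by MTT assay, with a stated time of 48 h; a higher number here means a weaker inhibitor, a lower number a stronger inhibitor:
Compound 1 `Cc1ccc(NC(=S)NC(=O)c2ccc(OCc3ccccc3)cc2)cc1-c1nc2ccccc2[nH]1`: 28800 nM
Compound 2 `Cc1ccc(NC(=S)NC(=O)c2ccc(OCc3ccccc3Cl)cc2)cc1-c1nc2ccccc2[nH]1`: 23700 nM

Compound 2 gives the lowest of these two numbers, but the step of a 1.2-fold lower number from compound 1 to compound 2 (0.08 log units; within the scatter) is within the scatter, so the two compounds cannot be told apart. Compound 3 `Cc1ccc(NC(=S)NC(=O)c2ccc(OCc3ccc(Cl)cc3Cl)cc2)cc1-c1nc2ccccc2[nH]1` differs from compound 2 by chloro in place of hydrogen on an aromatic carbon. Among the compounds with values here, the only measured step that bears on this change is a 1.2-fold lower number from compound 1 to compound 2 (0.08 log units; within the scatter), which was small. A comparable small step is therefore expected, a 1.2-fold lower number from compound 2 to compound 3 (0.07 log units; within the scatter), with no clear direction beyond the scatter. Compound 3 is estimated to give 20000 nM in this assay, expected between 8000 nM and 50000 nM.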

Compound 3, half-maximal inhibitory concentration: 11600 nM
Compound 3: middle estimate off by 1.7-fold (0.24 log units), on the high side; measured number inside the range.
By their numbers in this assay, from the lowest: compound 3; then compounds 2 and 1 (each within the scatter of the next).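

In this assay, within the data shown here, chloro in place of hydrogen, para to a large group, turns (2-chlorobenzyl)oxy into (2,4-dichlorobenzyl)oxy and gives a 2.0-fold lower number from compound 2 to compound 3 (0.31 log units; beyond the scatter), the first change on this ring to pass the scatter. Taken together, the two chloro groups give a 2.5-fold lower number from compound 1 to compound 3 (0.39 log units; beyond the scatter), so this ring does respond to substitution, though only modestly. Nothing available explains this shift.

On these data alone, whether a methoxy group or an amine at this position would lower the number further remains open. So does whether chloro here would give the same step without the 2-chloro group.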